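Tert-Butyl for Methyl on a Shared Core: Tolerated Concentration Outlook

This account rests on a few compounds, and the source may have more. Where it says the series, first, only, none or still open, it means among the compounds named here.

Compound 1 `CC(C)(C)c1ncc(Sc2nc[nH]n2)c(-c2ccccc2O)n1`: 160000 ug/mL
Compound 2 `Cn1ccnc1Sc1cnc(C(C)(C)C)nc1-c1cc(Cl)ccc1O`: 111000 ug/mL
Compound 3 `Cc1ncc(Sc2nccn2C)c(-c2ccccc2O)n1`: 577000 ug/mL

In an ADME assay on MDCK cells (Canis lupus familiaris) for cytotoxicity (a higher number here means that more compound is tolerated, a lower number that less compound is tolerated), compound 3 gives the highest of the three numbers, above compound 1 and further above compound 2, both gaps beyond the scatter. Compound 4 `Cn1ccnc1Sc1cnc(C(C)(C)C)nc1-c1ccccc1O` is reached from compound 3 by one change: tert-butyl in place of methyl on an aromatic carbon. Going by the values given here, no measured pair shows this change alone. Compound 1 and compound 2, which both carry the tert-butyl group but differ from compound 4 elsewhere, sit well below compound 3 in this assay, so a downward step of modest size, beyond the scatter, is expected. For compound 4 the estimated value is 230000 ug/mL (range 90000 ug/mL to 550000 ug/mL), an expected step of a 2.5-fold lower number from compound 3 to compound 4 (0.40 log units; beyond the scatter).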

Compound 4, half-maximal cytotoxic concentration: 194000 ug/mL
For compound 4 the middle estimate is 1.2-fold (0.07 log units) above the measured one; the range from low to high includes it.
By their numbers in this assay, from the lowest: compounds 2, 1 and 4 (each within the scatter of the next); then compound 3.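

Taken alone, tert-butyl in place of methyl on the aromatic carbon between two ring nitrogen atoms gives, in this assay, a 3.0-fold lower number from compound 3 to compound 4 (0.47 log units; beyond the scatter). With tert-butyl present, hydrogen in place of chloro gives a 1.7-fold higher number from compound 2 to compound 4 (0.24 log units; within the scatter), and 1-methyl-1H-imidazol-2-yl in place of 1H-1,2,4-triazol-3-yl on the sulfur gives a 1.2-fold higher number from compound 1 to compound 4 (0.08 log units; within the scatter). Nothing available explains the step from methyl to tert-butyl.

Open, from the compounds shown here alone, is how an ethyl group, an isopropyl group or an amine on this carbon would compare with methyl and tert-butyl. Also open, going by these compounds, is whether the same step appears in a compound carrying the chloro group or the 1H-1,2,4-triazol-3-yl group.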